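This account rests on a few compounds, and the source may have more. Where it says the series, first, only, none or still open, it means among the compounds named here.

Compound 3 `C=C(CC)C(=O)c1ccc(OCC(=O)Nc2ccc(/C=C/C(=O)O)cc2)c(Cl)c1Cl` gives 3000 nM in a functional assay on CLL cells (Homo sapiens) for cytotoxicity, read by MTT assay, with a stated time of 48 h (on this read-out higher numbers stand for an effect only at larger amounts of compound and lower numbers for an effect already at smaller amounts), the second highest of the three numbers seen so far. Its closest neighbour is compound 2 `C=C(CC)C(=O)c1ccc(OCC(=O)Nc2ccc(CC(=O)O)cc2)c(Cl)c1Cl`, which gives 3200 nM in this assay; compound 1 `C=C(CC)C(=O)c1ccc(OCC(=O)Nc2nc3ccccc3s2)c(Cl)c1Cl` gives 1500 nM, and both of these values lie within the scatter of compound 3. Compound 4 `C=C(CC)C(=O)c1ccc(OCC(=O)Nc2ccc(C(C)=O)cc2)c(Cl)c1Cl` differs from compound 3 by acetyl in place of 2-carboxyethenyl on an aromatic carbon. Within the data shown here, the only measured step at the same position, a 1.1-fold lower number from compound 2 to compound 3 (0.03 log units; within the scatter), exchanged one acid-bearing chain for another and changed nothing beyond the scatter. Among the measured compounds shown here, no measured step removes the acid itself, so the expectation rests on that single small step: a change of a 1.2-fold lower number from compound 3 to compound 4 (0.08 log units; within the scatter) is estimated, with no clear direction. Compound 4 is expected to give 2500 nM, within a range from 1000 nM to 6500 nM.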

Compound 4, half-maximal effective concentration: 3900 nM
Estimate against measurement, compound 4: 1.6-fold (0.19 log units) below; the range from low to high includes it.
By their numbers in this assay, from the lowest: compounds 1, 3, 2 and 4 (each within the scatter of the next, the first and the last beyond it).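

In this assay, acetyl on the aromatic carbon gives a number within the scatter of both acid-bearing chains (a 1.3-fold higher number from compound 3 to compound 4 (0.11 log units; within the scatter); a 1.2-fold higher number from compound 2 to compound 4 (0.09 log units; within the scatter)). Among these three compounds, then, the carboxylic acid is not required for this level of effect. The 4-acetylphenyl group on the amide-type nitrogen differs only modestly from 1,3-benzothiazol-2-yl (a 2.6-fold higher number from compound 1 to compound 4 (0.41 log units; beyond the scatter)), and no evidence explains either finding. Going by these compounds, whether an amine or a longer chain at this aromatic carbon would move the number beyond the scatter remains open.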